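Trimethoxyphenyl Swap in a Hydroxamate Indole Series

The source may report more compounds than this note shows. Statements on the series, on what has been measured and on what is new or still open speak of the compounds shown alone.

Measured compounds:
Compound 1 `COc1cc(C(=O)c2ccc3c(ccn3S(=O)(=O)c3ccc(/C=C/C(=O)NO)cc3)c2)cc(OC)c1OC`: 5340 nM
Compound 2 `COc1ccc(C(=O)c2ccc3c(ccn3Cc3ccc(C(=O)NO)cc3)c2)cc1OC`: 756 nM
Compound 3 `COc1cccc(C(=O)c2ccc3c(ccn3S(=O)(=O)c3cccc(/C=C/C(=O)NO)c3)c2)c1`: 3530 nM

In an assay on isolated protein for inhibition of histone deacetylase 8 (Homo sapiens) (on this read-out higher numbers stand for weaker inhibition and lower numbers for stronger inhibition), compound 3 stands second highest of the three numbers; compound 1 lies within the scatter of it, while compound 2 sits beyond the scatter with a lower number. Compound 4 `COc1cc(C(=O)c2ccc3c(ccn3S(=O)(=O)c3cccc(/C=C/C(=O)NO)c3)c2)cc(OC)c1OC` has not yet been measured. It differs from compound 3 in one place: 3,4,5-trimethoxyphenyl in place of 3-methoxyphenyl on a carbonyl carbon. Going by the values given here, no measured pair shows this change on its own, so the size of the step in this assay is not known from the data; compound 1, which also carries a 3,4,5-trimethoxyphenyl group, gives 5340 nM, so no step beyond the scatter is expected, at most a slight weakening. Compound 4 is therefore estimated at 4500 nM, between 2000 nM and 10000 nM, which means an expected step of a 1.3-fold higher number from compound 3 to compound 4 (0.11 log units; within the scatter).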

Compound 4, half-maximal inhibitory concentration: 1260 nM
For compound 4 the middle estimate is 3.6-fold (0.55 log units) above the measured one, and the stated range ends above it.
By their numbers in this assay, from the lowest: compounds 2 and 4 (each within the scatter of the next); then compounds 3 and 1 (each within the scatter of the next).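

In this assay, the change to 3,4,5-trimethoxyphenyl on the carbonyl carbon can now be read on its own, and it gives a 2.8-fold lower number from compound 3 to compound 4 (0.45 log units; beyond the scatter). The change on the sulfonyl sulfur, 3-(2-(hydroxycarbamoyl)ethenyl)phenyl in place of 4-(2-(hydroxycarbamoyl)ethenyl)phenyl, also matters, giving a 4.2-fold lower number from compound 1 to compound 4 (0.63 log units; beyond the scatter). Nothing available here explains either step. Going by these compounds, it remains open whether 3,4,5-trimethoxyphenyl gives a similar step in compounds without the sulfonyl link, and whether an aminophenyl or pyridyl group on the carbonyl carbon would do the same.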